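The compounds below may be only part of what the source reports. "The series", "measured", "known", "first", "only" and "open" are said of these compounds alone.

Working notes on the series in a functional assay on MIA PaCa-2 cells (Homo sapiens) for inhibition, read by MTT assay, with a stated time of 48 h, tested at 10 uM (a lower number here means less inhibition of growth, a higher number more inhibition of growth at the concentration tested), follow. Compound 1 `Cc1cc(=O)c2c(O)cc(OCc3ccc(Br)cc3)c([C@H]3CCN(C)C[C@H]3O)c2o1` gives 13% and compound 2 `Cc1cc(=O)c2c(O)c(CN3CCC(Cc4ccccc4)CC3)c(O)c([C@H]3CCN(C)C[C@H]3O)c2o1` gives 18% in this read-out. Compound 3 `Cc1cc(=O)c2c(O)c(CN(C)CC(=O)O)c(O)c([C@H]3CCN(C)C[C@H]3O)c2o1` gives 16% and lies within the scatter of both compound 2 and compound 1, so its place among the three numbers carries no order.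

Compound 4 `Cc1cc(=O)c2c(O)c(CN3CCCC3C(=O)O)c(O)c([C@H]3CCN(C)C[C@H]3O)c2o1` has not yet been measured. It carries 2-carboxypyrrolidin-1-yl in place of the (carboxymethyl)(methyl)amino of compound 3, on a saturated chain carbon bound to an aromatic carbon (2-carboxypyrrolidin-1-yl in place of (carboxymethyl)(methyl)amino on a saturated chain carbon bound to an aromatic carbon), so one five-membered non-aromatic ring enters the structure.

For the measured compounds named here, no two measured compounds differ in one place only, so the series offers no measured step as a guide to this change. The expectation rests on the values alone, with compound 3 at 16% and compound 2 at 18% on the same kind of chain carbon, and no step beyond the scatter is expected in this assay. The expected change is small, with a number 1 percentage points higher from compound 3 to compound 4 (within the scatter) as the estimated step. Compound 4 is estimated at 17% in this assay, with an expected range from 6% to 30% for the coming measurement.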

Compound 4, percent growth inhibition at one concentration: 10%
Compound 4: the middle estimate sits 7 percentage points above what was measured; the measured number falls inside the stated range.
By their numbers in this assay, from the lowest: compounds 4, 1, 3 and 2 (each within the scatter of the next).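

Closing the open chain into a ring, with 2-carboxypyrrolidin-1-yl in place of (carboxymethyl)(methyl)amino on a saturated chain carbon bound to an aromatic carbon, gives the first one-place step of the series in this assay (a number 6 percentage points lower from compound 3 to compound 4 (within the scatter)). At this place, then, the entry of one five-membered non-aromatic ring and of two further heavy atoms, with the carboxylic acid kept and the counted hydrogen-bond donors and acceptors unchanged, moves the read-out by no more than the usual scatter, so this assay separates compound 3 from compound 4 by no readable difference. Nothing available bears on why the read-out stays within the scatter for this change.

The compounds shown leave open whether the carboxylic acid itself matters at this place, which a methyl ester, a primary amide or a plain dimethylamino group on the same chain carbon would address. They also leave open whether a six-membered piperidine-2-carboxylic acid or a longer chain between the nitrogen and the acid would give a step beyond the scatter in this assay.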